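A Methyl Added to the Core of Compound 1

This account rests on a few compounds, and the source may have more. Where it says the series, first, only, none or still open, it means among the compounds named here.

Compound 1 `N=C(N)N/N=C/c1c(-c2cccs2)nc2sccn12` was tested in a functional assay on cells (Cancer cell lines, Homo sapiens) for inhibition (a higher number here means a weaker inhibitor of growth, a lower number a stronger inhibitor of growth), where compound 1 gives 12000 nM. Two related compounds were measured beside it: compound 2 `N=C(N)N/N=C/c1c(-c2ccsc2)nc2sccn12` gives 15100 nM and compound 3 `CCOC(=O)c1nc2sc(Cl)cn2c1/C=N\NC(=N)N` gives 19500 nM. Compound 1 sits at the low end of these three numbers, but the gap to compound 2 is a 1.3-fold higher number from compound 1 to compound 2 (0.10 log units; within the scatter), and the value of compound 3 likewise lies within the scatter of compound 1, so the three cannot be ranked.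

Compound 4 `Cc1cn2c(/C=N/NC(=N)N)c(-c3cccs3)nc2s1` is compound 1 with one change: methyl in place of hydrogen on an aromatic carbon. Within the data shown here, no measured step touches a methyl; the only step recorded, from compound 1 to compound 2, swapped thiophen-3-yl for thiophen-2-yl and moved the number by a 1.3-fold higher number from compound 1 to compound 2 (0.10 log units; within the scatter), a change of a different kind. There is therefore no basis for expecting a step beyond the scatter. Compound 4 is expected to show no change at the digits printed from compound 1 to compound 4 (within the scatter), and its estimated value in this assay is 12000 nM, within a range from 5000 nM to 30000 nM.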

Compound 4, concentration for 50% growth inhibition: 4270 nM
Estimate against measurement, compound 4: 2.8-fold (0.45 log units) above; the whole stated range lies above it.
By their numbers in this assay, from the lowest: compound 4; then compounds 1, 2 and 3 (each within the scatter of the next).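

In this assay methyl in place of hydrogen on an aromatic carbon next to the ring sulfur gives a 2.8-fold lower number from compound 1 to compound 4 (0.45 log units; beyond the scatter) and is the only step among these compounds that lies beyond the scatter. The one earlier step, thiophen-3-yl in place of thiophen-2-yl, changed a different part of the molecule and stayed within the scatter, so this position on the core is the first place shown where a single change moves the number, though only modestly. Nothing measured here bears on why the methyl has this effect.

As far as these compounds go, it remains open whether a longer chain such as ethyl, an amine or a carboxylic acid at this position would lower the number further, leave it unchanged or raise it. The compounds shown also leave open whether the same methyl step would appear with thiophen-3-yl in place of thiophen-2-yl, as in compound 2.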